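Hydroxy in place of fluoro on the aryl urea

The source may hold more compounds than are shown below. What is called first, only, known or untested is meant among the compounds shown, and "the series" means these compounds.

The series shares the core of compound 1 `COc1cc(NC(C)CCCNC(=O)Nc2cccc(F)c2)c2ncccc2c1`, which in a functional assay on MOLT-4 cells (Homo sapiens) for inhibition, read by MTT assay, with a stated time of 72 h (a lower number here means a stronger inhibitor, a higher number a weaker inhibitor), gives 23000 nM. Compound 2 `COc1cc(NC(C)CCCNC(=O)Nc2cccc(Cl)c2)c2ncccc2c1` gives 21000 nM, and compound 3 `COc1cc(NC(C)CCCNC(=O)NNC(=O)Nc2ccc(Br)cc2)c2ncccc2c1` gives 209000 nM. Compound 1 stands second highest of the three numbers; its nearest neighbour is compound 2 (a 1.1-fold lower number from compound 1 to compound 2 (0.04 log units; within the scatter)), its furthest compound 3 (a 9.1-fold higher number from compound 1 to compound 3 (0.96 log units; beyond the scatter)).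

Compound 4 `COc1cc(NC(C)CCCNC(=O)Nc2cccc(O)c2)c2ncccc2c1` differs from compound 1 by hydroxy in place of fluoro on an aromatic carbon.

Of the measured steps, only a 1.1-fold lower number from compound 1 to compound 2 (0.04 log units; within the scatter) changes a substituent on an aromatic carbon of that ring, and it lies within the scatter; but it exchanges one halogen for another, not for a hydroxy. The steps of a 9.1-fold higher number from compound 1 to compound 3 (0.96 log units; beyond the scatter) and a 10-fold higher number from compound 2 to compound 3 (1.00 log units; beyond the scatter) replace the whole 3-fluorophenyl or 3-chlorophenyl group with ((4-bromophenyl)carbamoyl)amino, so they do not test a single substituent at this place. Among the measured compounds shown here, no measured step bears directly on hydroxy in place of fluoro, and the data give no direction for it. The expectation is a step within or near the scatter, direction open: a 1.3-fold higher number from compound 1 to compound 4 (0.12 log units; within the scatter) is the estimated step. For compound 4 the estimate is 30000 nM, in a range from 9000 nM to 100000 nM.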

Compound 4, half-maximal inhibitory concentration: 24000 nM
For compound 4 the middle estimate is 1.3-fold (0.10 log units) above the measured one; measured number inside the range.
By their numbers in this assay, from the lowest: compounds 2, 1 and 4 (each within the scatter of the next); then compound 3.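

In this assay the substituent on this aromatic carbon can change in kind and not only from one halogen to another, since hydroxy sits with both halogens: a 1.0-fold higher number from compound 1 to compound 4 (0.02 log units; within the scatter) and a 1.1-fold higher number from compound 2 to compound 4 (0.06 log units; within the scatter) on the same aryl urea. Among the compounds shown here, the exchange adds a hydrogen-bond donor and a hydrogen-bond acceptor at a place meta to a large group, yet the number stays within the scatter, so across fluoro, chloro and hydroxy this place shows no preference in this cell read-out, while the one step beyond the scatter remains the change of the whole group, an 8.7-fold lower number from compound 3 to compound 4 (0.94 log units; beyond the scatter) in the direction of the 3-hydroxyphenyl urea. Nothing measured here accounts for the three substituents sitting together.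

The compounds shown leave open whether an amine or a carboxylic acid on this aromatic carbon would also stay level with fluoro, chloro and hydroxy, or would be the first single substituent to move the number beyond the scatter. Also open, from the compounds shown here alone, is whether hydroxy would behave the same way elsewhere on the ring, or with a longer chain between the shared core and the urea.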